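A sulfonyl swap on a compound at the assay limit

The source may report more compounds than this note shows. Statements on the series, on what has been measured and on what is new or still open speak of the compounds shown alone.

Compound 1 `CN(C)S(=O)(=O)c1ccc(F)c(C#Cc2cc(Cl)ccc2OCC(=O)O)c1` gives < 10 mL.min-1.g-1
Compound 2 `CCCS(=O)(=O)c1ccc(F)c(C#Cc2cc(Cl)ccc2OCC(=O)O)c1` gives 12 mL.min-1.g-1
Compound 3 `COCCNS(=O)(=O)c1ccc(C)c(C#Cc2cc(Cl)ccc2OCC(=O)O)c1` gives < 10 mL.min-1.g-1

All three compounds were tested in an in vitro ADME assay on microsomes from liver (Homo sapiens) for metabolic stability, read by LC-MS, tested at 1 uM; a lower number here means slower removal, a higher number faster removal of the compound. Compound 1 reports only a limit (< 10 mL.min-1.g-1) and not a number. Compound 3 also reports only a limit (< 10 mL.min-1.g-1) and not a number. What is known of compound 3 is therefore (the limit of < 10 mL.min-1.g-1 in this assay, at which 2 of the 3 values shown sit), so the step that follows has no exact starting number.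

Compound 4 `Cc1ccc(S(=O)(=O)N(C)CC(C)C)cc1C#Cc1cc(Cl)ccc1OCC(=O)O` has not been measured yet. It differs from compound 3 in one group: isobutyl(methyl)amino in place of (2-methoxyethyl)amino on a sulfonyl sulfur. In words, this is isobutyl(methyl)amino in place of (2-methoxyethyl)amino on a sulfonyl sulfur.

Among the compounds with values here, only one measured step changes a group at that same place, with propyl in place of dimethylamino: an at least 1.2-fold higher number from compound 1 to compound 2 (0.07 log units; that floor lies within the scatter). It is a single example with different groups, so it is only a weak guide. Resting on that step, a small upward move is expected, not clearly beyond the scatter. The estimated change is an at least 1.2-fold higher number from compound 3 to compound 4 (0.07 log units; that floor lies within the scatter). For compound 4 the expected value is 12 mL.min-1.g-1, with an estimated range from 6 mL.min-1.g-1 to 28 mL.min-1.g-1. The assay may again report only a limit.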

Compound 4, intrinsic clearance in microsomes: 79 mL.min-1.g-1
Compound 4: middle estimate off by 6.6-fold (0.82 log units), on the low side; measured number outside the range, above it.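

In this assay, the group on the sulfonyl sulfur now clearly matters, with the swap to isobutyl(methyl)amino giving an at least 7.9-fold higher number from compound 3 to compound 4 (0.89 log units; beyond the scatter). The earlier change at this place gave only an at least 1.2-fold higher number from compound 1 to compound 2 (0.07 log units; that floor lies within the scatter), so a large step here was not visible from that pair, which also has a different core from compound 3 and compound 4. The group that leaves, (2-methoxyethyl)amino, has 1 hydrogen-bond donor and 1 hydrogen-bond acceptor, and the group that enters has 0 of each, yet the data show only that the swap and the faster removal go together, and the printed step is just a floor because compound 3 gives a limit and not a number: the limit of < 10 mL.min-1.g-1 in this assay, at which 2 of the 4 values shown sit.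

The compounds shown leave open which part of the swap carries the rise, and a pair with isobutylamino and methyl(2-methoxyethyl)amino on the same sulfur would help pull apart the carbon chain, the oxygen and the amide hydrogen. They also leave open whether isobutyl(methyl)amino would give a similar step on the core of compound 1.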